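Dropping the Bromo from Compound 2

The source may hold more compounds than are shown below. What is called first, only, known or untested is meant among the compounds shown, and "the series" means these compounds.

Compound 1 `Fc1ccc(C2=NN(c3nc(-c4ccccc4)cs3)C(c3cccs3)C2)cc1`: 2340 nM
Compound 2 `Cc1ccc(C2=NN(c3nc(-c4ccc(Br)cc4)cs3)C(c3cccs3)C2)cc1`: 2010 nM

Both were tested in a functional assay on MCF7 cells (Homo sapiens) for antiproliferative activity, read by MTT assay, with a stated time of 48 h; a lower number here means a stronger inhibitor, a higher number a weaker inhibitor. For the measured compounds named here, compound 2 gives the lowest of the two numbers, though compound 1 lies within the scatter of it, and no single-point step links that pair. Compound 3 `Cc1ccc(C2=NN(c3nc(-c4ccccc4)cs3)C(c3cccs3)C2)cc1` awaits measurement; from compound 2 it differs by hydrogen in place of bromo on an aromatic carbon. Going by the values given here, with no measured step for this change, the closeness of compound 1 at 2340 nM is the only guide. The expected step of a 1.3-fold higher number from compound 2 to compound 3 (0.11 log units; within the scatter) is therefore small, if anything toward a higher number, and probably within the scatter. Compound 3 is estimated at 2600 nM, between 1200 nM and 5500 nM.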

Compound 3, half-maximal inhibitory concentration: 18600 nM
Compound 3: the middle estimate sits 7.2-fold (0.85 log units) below what was measured; the measured number lies above the stated range.
By their numbers in this assay, from the lowest: compounds 2 and 1 (each within the scatter of the next); then compound 3.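

In this assay the change from 4-bromophenyl to phenyl is not a silent one: a 9.3-fold higher number from compound 2 to compound 3 (0.97 log units; beyond the scatter) shows that the bromo at this place carries weight. The second aromatic position counts as well, since with phenyl kept, methyl in place of fluoro gives a 7.9-fold higher number from compound 1 to compound 3 (0.90 log units; beyond the scatter) as a second step beyond the scatter. Nothing available accounts for either step.

On these data alone, whether a chloro, a methoxy or an amine in place of the bromo would hold the lower number remains open. So does how bromo and fluoro would act together in one compound.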